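Chloro to Bromo Swap: Cytotoxicity Expected to Stay Low

The source may hold more compounds than are shown below. What is called first, only, known or untested is meant among the compounds shown, and "the series" means these compounds.

In an ADME assay on Huh-7 cells (Homo sapiens) for cytotoxicity (on this read-out lower numbers stand for higher toxicity in this test and higher numbers for lower toxicity in this test), compound 1 `O=c1cc(CNCc2ccccc2)oc2ccc(O)c(O)c12` gives > 100000 nM, which is a limit of the test rather than a measured number. Compound 2 `O=c1cc(CNCc2ccccc2Cl)oc2ccc(O)c(O)c12` shows the same picture: in this assay compound 2 gives > 100000 nM, again a limit. The addition of chlorine therefore yields a step that the two limits leave unreadable from compound 1 to compound 2, because both readings rest at the limit of > 100000 nM in this assay, at which 2 of the 2 values shown sit.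

Compound 3 `O=c1cc(CNCc2ccccc2Br)oc2ccc(O)c(O)c12` is built from compound 1 by bromo in place of hydrogen on an aromatic carbon. Within the data shown here, the only measured step that resembles this change, the one from compound 1 to compound 2, could not be sized, so no shift beyond the scatter can be predicted in either direction. Compound 3 is therefore expected to land at the limit as well, an estimated 100000 nM with a range from 40000 nM to 100000 nM, meaning an expected a number no higher from compound 1 to compound 3 (the limit leaves the size open).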

Compound 3, half-maximal cytotoxic concentration: > 100000 nM
Compound 3: a limit, no number (the forecaster's own chance of this, stated with the estimate: 85%); the middle value sits exactly at the limit.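

Among these compounds, compound 3 also reads as a limit rather than a number, so no step among compound 1, compound 2 and compound 3 can be read: the limit of > 100000 nM in this assay, at which 3 of the 3 values shown sit.

The compounds shown leave open whether chloro or bromo in place of hydrogen shifts the reading in this assay at all.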